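This account rests on a few compounds, and the source may have more. Where it says the series, first, only, none or still open, it means among the compounds named here.

Series notes, step from compound 3 to compound 4.

Of the compounds shown here, three of the shared core have been measured in a functional assay on MCF7 cells (Homo sapiens) for antiproliferative activity, read by MTT assay, with a stated time of 72 h; on this read-out higher numbers stand for weaker inhibition and lower numbers for stronger inhibition. Compound 1 `COc1ncc(-c2ccc3nc(NC(=O)NC4CC4)sc3c2)cc1NS(=O)(=O)c1ccc(F)cc1` gives 1190 nM. Compound 2 `COc1ncc(-c2ccc3nc(NC4CC4)sc3c2)cc1NS(=O)(=O)c1ccc(F)cc1` gives 450 nM. Going by the values given here, the one measured step between them, a 2.6-fold lower number from compound 1 to compound 2 (0.42 log units; beyond the scatter), concerns the urea end of the core and not the pyridine substituent. Compound 3 `CCN(CC)CCNC(=O)Nc1nc2ccc(-c3cnc(Cl)c(NS(=O)(=O)c4ccc(F)cc4)c3)cc2s1`, which carries a diethylaminoethyl urea and a chloro on the pyridine, gives 710 nM in this assay; that number sits within the usual scatter of both compound 2 and compound 1, so no ordering among the three is claimed.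

Compound 4 `CCN(CC)CCNC(=O)Nc1nc2ccc(-c3cnc(OC)c(NS(=O)(=O)c4ccc(F)cc4)c3)cc2s1` keeps the diethylaminoethyl urea of compound 3 and differs only at the pyridine: methoxy in place of chloro on an aromatic carbon. Among the compounds with values here, compounds 1 and 2 already carry a methoxy at that place, but both also differ from compound 3 at the urea, so no measured step isolates the chloro-to-methoxy exchange. The lone measured step, from compound 1 to compound 2, does not bear on it. Within the data shown here, with no direct precedent, the expected step of a 1.0-fold lower number from compound 3 to compound 4 (0.01 log units; within the scatter) is none beyond the scatter, in either direction. Compound 4 is therefore estimated at 700 nM in this assay, with a range from 300 nM to 1700 nM.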

Compound 4, half-maximal inhibitory concentration: 320 nM
The estimate for compound 4 lay 2.2-fold (0.34 log units) above the measured number, within the range that was stated.
By their numbers in this assay, from the lowest: compounds 4, 2, 3 and 1 (each within the scatter of the next, the first and the last beyond it).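

Going by these compounds alone, with the diethylaminoethyl urea held constant, methoxy in place of chloro on the aromatic carbon next to the ring nitrogen gives a 2.2-fold lower number from compound 3 to compound 4 (0.35 log units; beyond the scatter) in this assay and so provides the first isolated reading of this position, which the earlier compounds could not supply. With the methoxy held constant, the urea end also matters: 2-(diethylamino)ethyl in place of cyclopropyl on the amide-type nitrogen gives a 3.7-fold lower number from compound 1 to compound 4 (0.57 log units; beyond the scatter) while (2-(diethylamino)ethyl)carbamoyl in place of cyclopropyl on the aromatic-ring nitrogen gives a 1.4-fold lower number from compound 2 to compound 4 (0.15 log units; within the scatter) and therefore separates compound 2 from compound 4 by no more than the scatter. No measurement at hand explains the methoxy-for-chloro step, which remains an observation in this one urea setting.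

From the compounds shown here alone, whether the step carries over to the cyclopropyl urea of compound 1 or the cyclopropylamino end of compound 2 remains open. Also open, going by these compounds, is how an ethoxy group, a dimethylamino group or a plain hydrogen at this position would read, and whether a morpholine in place of the diethylamino group would retain the reading of compound 4.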